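A few compounds are considered here, and "the series" means these few. Any claim that something is new, unique, unknown or untested is made for them only; others in the source may bear on it.

Measured so far:

- compound 1, `CC1CCCN1C1CCN(c2ccc(NC(=O)CC3CCCC3)cc2)C1`: in an assay on CHO cells for displacement of a labelled ligand from histamine receptor H3 (Macaca mulatta) (a lower number here means a stronger inhibitor, a higher number a weaker inhibitor), compound 1 gives 3.1 nM
- compound 2, `CC(=O)N1CCCC1C(=O)Nc1ccc(N2CCC(N3CCCC3C)C2)c(C)c1`: in this assay compound 2 gives 44.9 nM
- compound 3, `Cc1cc(N2CCC(N3CCCC3C)C2)ccc1NC(=O)C1CCOCC1`: in this assay compound 3 gives 6.8 nM

Among these three, compound 1 has the lowest number, and so the strongest binding. Compound 3 comes nearest, its number being higher by a margin beyond the usual scatter, while compound 2 lies furthest away with a markedly higher number.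

The step of interest leads from compound 1 to a compound not yet measured, compound 4, `CC1CCCN1C1CCN(c2ccc(NC(=O)C3C(C)(C)C3(C)C)cc2)C1`. The shared core of compound 1 is kept; the change is 2,2,3,3-tetramethylcyclopropyl in place of cyclopentylmethyl on a carbonyl carbon. Both the group that leaves and the group that enters are small, saturated, carbon-only rings with no hydrogen-bond donors or acceptors and no charge, so nothing in the measured compounds points to a shift of one kind or the other. Going by the values given here, no step between measured compounds shows this exchange, so the expectation is that compound 4 stays close to compound 1, with a step of a 1.3-fold higher number from compound 1 to compound 4 (0.11 log units; within the scatter) that does not clearly exceed the scatter. The estimated value for compound 4 in this assay is 4 nM, with a range from 1.5 nM to 12 nM.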

Compound 4, inhibition constant: 144 nM
For compound 4 the middle estimate is 36-fold (1.56 log units) below the measured one, and the stated range ends below it.
By their numbers in this assay, from the lowest: compound 1; then compound 3; then compound 2; then compound 4.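

Exchanging cyclopentylmethyl for 2,2,3,3-tetramethylcyclopropyl on a carbonyl carbon is far from a neutral swap: in this assay it brings a 46-fold higher number from compound 1 to compound 4 (1.67 log units; beyond the scatter) and shows that this place on the core of compound 1 can respond strongly to a change of one carbon-only ring for another. The two groups match in having no hydrogen-bond donors, no hydrogen-bond acceptors and no net charge, so these shared features alone do not tell how such an exchange will turn out. No measurement given here explains the step.

On these data alone, it remains open whether the four methyl groups or the three-membered ring accounts for the step, and an unsubstituted cyclopropyl group on the same carbonyl carbon would help separate the two. As far as these compounds go, how a longer chain or an amine would fare at this place also remains open.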